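The source may report more compounds than this note shows. Statements on the series, on what has been measured and on what is new or still open speak of the compounds shown alone.

Compound 2 `CCOC(=O)c1oc2ccc(NS(=O)(=O)c3cccc([N+](=O)[O-])c3)cc2c1C` and compound 1 `CCOC(=O)c1oc2ccc(NS(=O)(=O)c3ccc([N+](=O)[O-])cc3)cc2c1C` share one core and differ only in the nitro group on the sulfonyl-bound ring. In a functional assay on MCF7 cells (Homo sapiens) for antiproliferative activity, read by MTT assay, with a stated time of 72 h (on this read-out higher numbers stand for weaker inhibition and lower numbers for stronger inhibition), compound 1 gives 69600 nM, and in the same test compound 2 gives 74800 nM. Within the data shown here, the only measured step, a 1.1-fold higher number from compound 1 to compound 2 (0.03 log units; within the scatter), leaves the two numbers within the scatter of each other, so compound 2 stands level with compound 1 rather than apart from it.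

Compound 3 `CCOC(=O)c1oc2ccc(NS(=O)(=O)c3cccs3)cc2c1C` carries the change (thiophen-2-yl in place of 3-nitrophenyl on a sulfonyl sulfur). Among the measured compounds shown here, no measured step here swaps one aromatic ring for another; the single known step moves a nitro group within a ring and so offers no guide to this change. With nothing to point either way, compound 3 is expected to sit close to compound 2 in this assay, a step of a 1.1-fold higher number from compound 2 to compound 3 (0.03 log units; within the scatter). The estimated value for compound 3 is 80000 nM, with a range from 25000 nM to 250000 nM.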

Compound 3, half-maximal inhibitory concentration: 92300 nM
Compound 3: middle estimate off by 1.2-fold (0.06 log units), on the low side; the range from low to high includes it.
By their numbers in this assay, from the lowest: compounds 1, 2 and 3 (each within the scatter of the next).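

Here the whole ring on the sulfonyl sulfur is exchanged, not just the place of a nitro group, and thiophen-2-yl brings a five-membered ring with sulfur and no nitro group. In this assay this gives a 1.2-fold higher number from compound 2 to compound 3 (0.09 log units; within the scatter) and a 1.3-fold higher number from compound 1 to compound 3 (0.12 log units; within the scatter) so all three compounds stand level. Among these three compounds, then, neither the six-membered carbon ring nor the nitro group is needed to keep the number at this level, although no measurement explains why this is so.

All the groups shown at this position are aromatic rings, so a plain methyl group or a longer alkyl chain on the sulfonyl sulfur remains an open case. So does a phenyl ring carrying an amine or a carboxylic acid, and either might yet move the number beyond the scatter.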